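Ethylsulfonyl for fluoroethyl carbamate on the piperidine nitrogen

The compounds below may be only part of what the source reports. "The series", "measured", "known", "first", "only" and "open" are said of these compounds alone.

Measured so far:
compound 1, `CCCOC(=O)N1CCC(Oc2ncnc3c2CCN3c2ccc(S(C)(=O)=O)cc2F)CC1`: 79.4 nM
compound 2, `CS(=O)(=O)c1ccc(N2CCc3c(OC4CCN(C(=O)OCCF)CC4)ncnc32)c(F)c1`: 501 nM

In a functional assay on CHO-K1 cells for agonist activity at Glucose-dependent insulinotropic receptor (Homo sapiens), read by a luciferase reporter, with a stated time of 5 h (a lower number here means that less compound is needed, a higher number that more compound is needed for the effect), compound 2 gives 501 nM, the highest of the two numbers measured; its nearest neighbour is compound 1 with 79.4 nM, and the step of a 6.3-fold higher number from compound 1 to compound 2 (0.80 log units; beyond the scatter) is modest but beyond the scatter. Compound 3, `CCS(=O)(=O)N1CCC(Oc2ncnc3c2CCN3c2ccc(S(C)(=O)=O)cc2F)CC1`, has not been measured. It differs from compound 2 in one place: ethylsulfonyl in place of (2-fluoroethoxy)carbonyl on an amine nitrogen in a ring. Within the data shown here, no measured step bears directly on this change; the only step, from compound 1 to compound 2, alters the carbamate chain and not the kind of group on the amine nitrogen in a ring. The direction for compound 3 is therefore open, and a step in this assay of about a 1.3-fold lower number from compound 2 to compound 3 (0.10 log units; within the scatter) is expected, with a wide range. Compound 3 is estimated to give 400 nM, expected between 80 nM and 2000 nM.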

Compound 3, half-maximal effective concentration: 1580 nM
Compound 3: middle estimate off by 4.0-fold (0.60 log units), on the low side; low and high end bracket the measured number.
By their numbers in this assay, from the lowest: compound 1; then compound 2; then compound 3.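

Until now, only the chain of the carbamate had varied. Compound 3 shows that the kind of group on the amine nitrogen in a ring also matters: in this assay, ethylsulfonyl in place of (2-fluoroethoxy)carbonyl gives a 3.2-fold higher number from compound 2 to compound 3 (0.50 log units; beyond the scatter) and the same group in place of propoxycarbonyl gives a 20-fold higher number from compound 1 to compound 3 (1.30 log units; beyond the scatter) so that both carbamates shown need less compound for the effect than the ethylsulfonyl compound. No measurement here explains this difference.

Going by these compounds, it remains open whether the drop belongs to the sulfonyl link itself or to the ethyl chain on it, since a longer chain on the sulfonyl group could behave differently. An amide or a urea on the same nitrogen would show whether anything other than a carbamate can match compound 1.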